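Hydroxy on the Saturated Ring of an Oxalamide Series

The compounds below may be only part of what the source reports. "The series", "measured", "known", "first", "only" and "open" are said of these compounds alone.

Measured compounds:
compound 1, `O=C(Nc1ccc(Cl)cc1)C(=O)N1CCC(c2ccnc3ccc(F)cc23)CC1`: 97 mL.min-1.g-1
compound 2, `N#Cc1ccc(NC(=O)C(=O)N2CCC(c3ccnc4ccc(F)cc34)CC2)cc1`: 28 mL.min-1.g-1
compound 3, `O=C(Nc1ccc(C(F)F)cc1)C(=O)N1CCC(c2ccnc3ccc(F)cc23)CC1`: 76 mL.min-1.g-1

Of the compounds shown here, three sharing one core have been measured in an ADME assay on microsomes from liver (Mus musculus) for metabolic stability; a higher number here means faster removal of the compound, a lower number slower removal. Compound 1 gives 97 mL.min-1.g-1, the highest of the three numbers; compound 3 sits nearest, with a 1.3-fold lower number from compound 1 to compound 3 (0.11 log units; within the scatter), while compound 2 is furthest, with a 3.5-fold lower number from compound 1 to compound 2 (0.54 log units; beyond the scatter). The remaining pair shows a 2.7-fold higher number from compound 2 to compound 3 (0.43 log units; beyond the scatter).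

Compound 4, `O=C(Nc1ccc(Cl)cc1)C(=O)N1CC[C@@H](c2ccnc3ccc(F)cc23)[C@H](O)C1`, has not yet been measured in this assay. It differs from compound 1 by hydroxy in place of hydrogen on a saturated ring carbon.

Going by the values given here, none of the measured steps bears directly on this change: each of them swaps a group on an aromatic carbon, whereas the change to compound 4 falls on a saturated ring carbon of the core. The two steps that were beyond the scatter, from compound 1 to compound 2 and from compound 2 to compound 3, were modest in size, and the third lay within the scatter; these give the scale of what a single change has done here so far. Among the compounds with values here, with no step of the same kind on record, the expectation for compound 4 rests on the position of compound 1 alone, and a modest move downward is expected: a 1.9-fold lower number from compound 1 to compound 4 (0.29 log units; within the scatter). Compound 4 is estimated at 50 mL.min-1.g-1, within a range from 20 mL.min-1.g-1 to 120 mL.min-1.g-1.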

Compound 4, intrinsic clearance in microsomes: 18 mL.min-1.g-1
For compound 4 the middle estimate is 2.8-fold (0.44 log units) above the measured one; measured number outside the range, below it.
By their numbers in this assay, from the lowest: compounds 4 and 2 (each within the scatter of the next); then compounds 3 and 1 (each within the scatter of the next).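

In this assay, going by these compounds alone, the first change on the saturated ring of the core gives a 5.4-fold lower number from compound 1 to compound 4 (0.73 log units; beyond the scatter), a step beyond the scatter. Within the data shown here, all the earlier steps swapped a group on an aromatic carbon, so this is the first sign that a single change on a saturated ring carbon, two ring bonds from the ring nitrogen and next to the ring atom that bears a large group, also registers in this assay, and here hydroxy in place of hydrogen goes with a lower number. Nothing available explains this step or tells what it rests on.

The compounds shown leave open whether the lower number belongs to hydroxy itself or would also come with a methoxy, a fluoro or an amine on the same saturated ring carbon, and whether the opposite spatial arrangement of the hydroxy would give the same result. They also leave open whether the step would carry over to the cyano of compound 2 or the difluoromethyl of compound 3, since hydroxy is shown here only with the chloro of compound 1.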